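This account rests on a few compounds, and the source may have more. Where it says the series, first, only, none or still open, it means among the compounds named here.

Measured so far in a functional assay on brain (Rattus norvegicus, strain Wistar) for inhibition; on this read-out lower numbers stand for stronger inhibition and higher numbers for weaker inhibition:
compound 1 `Cc1[nH]c(=O)n(C)c1-c1ccc(OC(C)C)cc1` — 20400 nM
compound 2 `Cc1[nH]c(=O)n(C)c1-c1ccc(C(C)(C)C)cc1` — 8400 nM
compound 3 `Cc1[nH]c(=O)n(C2CCCCC2)c1-c1ccc(OC(C)C)cc1` — 13000 nM

Compound 3 stands second highest of the three numbers; its gaps to compound 2 and to compound 1 both lie within the scatter, so no order among the three follows from these values. Compound 4 `CCCCCCCCc1ccc(-c2c(C)[nH]c(=O)n2C2CCCCC2)cc1` is not yet measured. Compared with compound 3 the change is octyl in place of isopropoxy on an aromatic carbon. Going by the values given here, the one measured step bearing on a change at this aromatic carbon is a 2.4-fold lower number from compound 1 to compound 2 (0.39 log units; beyond the scatter), where a hydrocarbon group likewise replaced the isopropoxy; the step of a 1.6-fold lower number from compound 1 to compound 3 (0.20 log units; within the scatter) concerns the aromatic nitrogen and is not informative here. Octyl is not tert-butyl, so the step carries over only loosely, and a modest lowering of the number is expected, a 2.2-fold lower number from compound 3 to compound 4 (0.34 log units; beyond the scatter). Compound 4 is estimated at 6000 nM, with a range from 2000 nM to 18000 nM.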

Compound 4, half-maximal inhibitory concentration: 10300 nM
The estimate for compound 4 lay 1.7-fold (0.23 log units) below the measured number; the measured number falls inside the stated range.
By their numbers in this assay, from the lowest: compounds 2, 4, 3 and 1 (each within the scatter of the next, the first and the last beyond it).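

In this assay, octyl in place of isopropoxy on the aromatic carbon gives a 1.3-fold lower number from compound 3 to compound 4 (0.10 log units; within the scatter), so with cyclohexyl on the aromatic nitrogen this carbon carries a chain of 8 heavy atoms, without the hydrogen-bond acceptor of isopropoxy, and the number shifts by no more than the scatter. The earlier compounds shown here showed a hydrocarbon replacement here only as tert-butyl, with methyl on that nitrogen. No measurement on hand accounts for this result. Still open, going by these compounds, is whether tert-butyl behaves the same with cyclohexyl on the nitrogen. An amine or carboxylic acid at this carbon also remains untested among the compounds shown.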